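Chloro for methoxy on the benzyl ring of compound 3

A few compounds are considered here, and "the series" means these few. Any claim that something is new, unique, unknown or untested is made for them only; others in the source may bear on it.

The series shares one core carrying a substituted benzyl group and an aryl group. In a functional assay on CHO-K1 cells for antagonist activity at adenosine receptor A1 (Homo sapiens), read by a beta-galactosidase reporter and cAMP accumulation, with stated times of 15 min and 6 h (a lower number here means a stronger inhibitor, a higher number a weaker inhibitor), compound 1 `Cc1ccc(-c2nc(N)c3cc(Cc4ccccc4Cl)sc3n2)o1` gives 26.1 nM, and compound 2 `Cc1csc(-c2nc(N)c3cc(Cc4ccccc4Cl)sc3n2)n1` gives 49.6 nM; the step of a 1.9-fold higher number from compound 1 to compound 2 (0.28 log units; within the scatter) lies within the scatter. Compound 3 `COc1ccccc1Cc1cc2c(N)nc(-c3cccc(C#N)c3)nc2s1` gives 129 nM in this assay, the highest of the three numbers, beyond the scatter from both compound 2 and compound 1.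

Compound 4 `N#Cc1cccc(-c2nc(N)c3cc(Cc4ccccc4Cl)sc3n2)c1` differs from compound 3 by chloro in place of methoxy on an aromatic carbon. Among the compounds with values here, no measured pair isolates this change: compound 1 and compound 2 carry the chlorobenzyl, but they also differ from compound 3 in the aryl group, so their lower numbers cannot be assigned to the benzyl substituent alone. Within the data shown here, the only single-point step measured, from compound 1 to compound 2, concerns the aryl group and is within the scatter. For compound 4 the expected step of a 1.8-fold lower number from compound 3 to compound 4 (0.27 log units; within the scatter) in this assay is therefore modest, tending toward a lower number, with a wide range. Compound 4 is estimated at 70 nM, between 25 nM and 200 nM.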

Compound 4, inhibition constant: 24.8 nM
The estimate for compound 4 lay 2.8-fold (0.45 log units) above the measured number, outside the stated range (below it).
By their numbers in this assay, from the lowest: compounds 4, 1 and 2 (each within the scatter of the next); then compound 3.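

In this assay, within the data shown here, the step of a 5.2-fold lower number from compound 3 to compound 4 (0.72 log units; beyond the scatter) is the first measured pair to isolate 2-methoxybenzyl to 2-chlorobenzyl, with 3-cyanophenyl held constant, and it lies beyond the scatter, so the series responds to this change at this position. With 2-chlorobenzyl held constant, the steps of a 2.0-fold lower number from compound 2 to compound 4 (0.30 log units; within the scatter) and a 1.1-fold lower number from compound 1 to compound 4 (0.02 log units; within the scatter) both lie within the scatter, so 3-cyanophenyl, 4-methyl-1,3-thiazol-2-yl and 5-methylfuran-2-yl are not separated in this assay. Nothing available here accounts for the step from methoxy to chloro.

The compounds shown leave open how a fluoro, a methyl or an amine in place of chloro would read at this position. They also leave open whether methoxy to chloro gives a step of similar size with 5-methylfuran-2-yl or 4-methyl-1,3-thiazol-2-yl as the aryl group.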